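Replacing a phenethyl link with a phenylethenyl link

This account rests on a few compounds, and the source may have more. Where it says the series, first, only, none or still open, it means among the compounds named here.

Measured compounds:
Compound 1, `CC(C(=O)NCc1ccc(C(F)(F)F)nc1-c1ccccc1F)c1ccc(NS(C)(=O)=O)c(F)c1`, 63.3 nM
Compound 2, `CC(C(=O)NCc1ccc(C(F)(F)F)nc1CCc1ccccc1)c1ccc(NS(C)(=O)=O)c(F)c1`, 1.4 nM

Of the compounds shown here, two have been measured in an assay on CHO cells for antagonist activity at transient receptor potential cation channel subfamily V member 1 (Homo sapiens), read by FLIPR; on this read-out lower numbers stand for stronger inhibition and higher numbers for weaker inhibition. Compound 1 gives 63.3 nM, while compound 2 gives 1.4 nM. Among the measured compounds shown here, the one step between them, a 45-fold lower number from compound 1 to compound 2 (1.66 log units; beyond the scatter), is large, and compound 2 therefore stands at the lowest number of the two, with compound 1 as its only neighbour at a much higher number.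

Compound 3, `CC(C(=O)NCc1ccc(C(F)(F)F)nc1/C=C/c1ccccc1)c1ccc(NS(C)(=O)=O)c(F)c1`, has not yet been measured. It differs from compound 2 in one place: 2-phenylethenyl in place of phenethyl on an aromatic carbon. For the measured compounds named here, the only measured step, a 45-fold lower number from compound 1 to compound 2 (1.66 log units; beyond the scatter), concerns the same position, where a group attached directly to the ring gave way to a two-carbon link; it does not cover the exchange of a saturated two-carbon link for one with a double bond. Going by the values given here, there is thus no direct precedent for the step to compound 3, and the expectation rests on compound 2 alone. A modest rise in the number is expected, well short of the span from compound 1 to compound 2, so that compound 3 is estimated at 5 nM, between 1.2 nM and 25 nM, which would mean a 3.6-fold higher number from compound 2 to compound 3 (0.55 log units; beyond the scatter) in this assay.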

Compound 3, inhibition constant: 2.2 nM
Compound 3: the middle estimate sits 2.3-fold (0.36 log units) above what was measured; the range from low to high includes it.
By their numbers in this assay, from the lowest: compounds 2 and 3 (each within the scatter of the next); then compound 1.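

In this assay, putting 2-phenylethenyl in place of phenethyl on the aromatic carbon next to the ring nitrogen gives a 1.6-fold higher number from compound 2 to compound 3 (0.20 log units; within the scatter) and so the double bond outside the aromatic rings makes no difference that this read-out can resolve. The low number is therefore not tied to the saturated link alone, for 2-phenylethenyl in place of 2-fluorophenyl gives a 29-fold lower number from compound 1 to compound 3 (1.46 log units; beyond the scatter) and this step is large, as is a 45-fold lower number from compound 1 to compound 2 (1.66 log units; beyond the scatter) with phenethyl at the same carbon. Nothing further is available that would explain why these two links behave alike here.

The compounds shown leave open how far this tolerance extends, whether to a shorter benzyl group, a longer 3-phenylpropyl chain or a phenylethynyl group with a triple bond in the link. They also leave open whether the cis form of 2-phenylethenyl would match the trans form carried by compound 3, and whether substituents such as fluorine on the terminal phenyl ring would shift the number in either direction.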